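From dimethoxyphenyl to furan-2-yl: what size of step?

This account rests on a few compounds, and the source may have more. Where it says the series, first, only, none or still open, it means among the compounds named here.

Measured so far in a functional assay on SMMC-7721 cells (Homo sapiens) for cytotoxicity, read by MTT assay, with a stated time of 72 h; a lower number here means a stronger inhibitor, a higher number a weaker inhibitor:
Compound 1 `O=C1C(=Cc2ccc(F)cc2)C(=O)N(c2ccc(Cl)cc2)N1c1ccc(Cl)cc1` gives 23300 nM
Compound 2 `COc1ccc(C=C2C(=O)N(c3ccc(Cl)cc3)N(c3ccc(Cl)cc3)C2=O)cc1OC` gives > 128000 nM (a limit of the assay, not a number)
Compound 3 `COc1cccc(C=C2C(=O)N(c3ccc(Cl)cc3)N(c3ccc(Cl)cc3)C2=O)c1OC` gives 14100 nM

Compound 3 (14100 nM) lies within the usual scatter of compound 1 (23300 nM), so neither can be ranked above the other. Compound 2 has only a limit (> 128000 nM) and no exact number.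

Compound 4 `O=C1C(=Cc2ccco2)C(=O)N(c2ccc(Cl)cc2)N1c1ccc(Cl)cc1` carries furan-2-yl in place of 2,3-dimethoxyphenyl on a double-bonded chain carbon bound to a double-bonded ring carbon.

All three measured steps changed the group at this same place. One stayed small (a 1.7-fold lower number from compound 1 to compound 3 (0.22 log units; within the scatter)), while two were larger (an at least 5.4-fold higher number from compound 1 to compound 2 (0.73 log units; beyond the scatter); an at least 9.0-fold lower number from compound 2 to compound 3 (0.95 log units; beyond the scatter)) and rest on the limit of compound 2. Among the measured compounds shown here, a swap here can therefore do little or a great deal, and no measured compound carries furan-2-yl. Two of the three compounds still gave close numbers (a 1.7-fold lower number from compound 1 to compound 3 (0.22 log units; within the scatter)), so no step beyond the scatter is expected in this assay, with a slight lean towards a higher number. The expected change is a 1.8-fold higher number from compound 3 to compound 4 (0.25 log units; within the scatter) and no more than an estimate. For compound 4 the estimated value is 25000 nM with an expected range from 8000 nM to 90000 nM as its bounds.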

Compound 4, half-maximal inhibitory concentration: 19500 nM
Compound 4: middle estimate off by 1.3-fold (0.11 log units), on the high side, within the range that was stated.
By their numbers in this assay, from the lowest: compounds 3, 4 and 1 (each within the scatter of the next). At a limit, above all of these: compound 2.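

In this assay, furan-2-yl has 5 heavy atoms and a five-membered aromatic ring, yet putting it in place of 2,3-dimethoxyphenyl gives a 1.4-fold higher number from compound 3 to compound 4 (0.14 log units; within the scatter), and putting it in place of 4-fluorophenyl gives a 1.2-fold lower number from compound 1 to compound 4 (0.08 log units; within the scatter), so three quite different groups at this place cannot be told apart. Only 3,4-dimethoxyphenyl stands apart, as an at least 6.5-fold lower number from compound 2 to compound 4 (0.81 log units; beyond the scatter) shows, so the large steps seen at this place trace to that one group and not to ring size or to a move away from a ring of carbon only. That step rests on compound 2, whose value is a limit of the assay and not a number: the limit of > 128000 nM in this assay, at which 1 of the 4 values shown sits.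

Still open, on these data alone, is whether an aromatic ring is needed on the double-bonded chain carbon at all, a question that a longer alkyl chain or an amine in that place could help to answer. Also open, as far as these compounds go, is whether any change to the group here, or to the rest of the core, which is the same in all four compounds, could take the number clearly below those of compounds 1, 3 and 4.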